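A few compounds are considered here, and "the series" means these few. Any claim that something is new, unique, unknown or untested is made for them only; others in the source may bear on it.

Measured compounds:
- compound 1, `Clc1ccc(Cn2cc(CSc3nnc(-c4ccccc4)c(-c4ccccc4)n3)nn2)cc1`, in a functional assay on ECa-109 cells for antiproliferative activity against ECa-109 cell line (Homo sapiens), read by MTT assay, with a stated time of 48 h (a lower number here means a stronger inhibitor, a higher number a weaker inhibitor), compound 1 gives 24200 nM
- compound 2, `COc1ccc(Cn2cc(CSc3nnc(-c4ccccc4)c(-c4ccccc4)n3)nn2)cc1`, in this assay compound 2 gives 28400 nM

For the measured compounds named here, compound 2 holds the highest of the two numbers, but its only neighbour is compound 1, and the step of a 1.2-fold higher number from compound 1 to compound 2 (0.07 log units; within the scatter) is within the scatter, so the two compounds cannot be told apart on these data. That single step, methoxy in place of chloro on an aromatic carbon, is the whole measured record for this series.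

Compound 3, `NS(=O)(=O)c1ccc(-n2cc(CSc3nnc(-c4ccccc4)c(-c4ccccc4)n3)nn2)cc1`, has not yet been measured. It differs from compound 2 in one place: 4-sulfamoylphenyl in place of 4-methoxybenzyl on an aromatic nitrogen. Going by the values given here, no measured step touches the group on the ring nitrogen itself; the one step that exists, the swap of the para substituent on the benzyl ring, changed nothing beyond the scatter. There is therefore no basis in these numbers for expecting a shift in either direction in this assay, and the expected step of a 1.1-fold lower number from compound 2 to compound 3 (0.06 log units; within the scatter) is put at about none, with a wide band of uncertainty around it. On that basis compound 3 is estimated at 25000 nM, expected to lie between 7000 nM and 90000 nM.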

Compound 3, half-maximal inhibitory concentration: > 100000 nM
Compound 3 was reported as a limit; the forecaster's own chance of this, stated with the estimate: 15%; at least 4.0-fold (0.60 log units) between middle value and limit.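

In this assay, the group on the aromatic nitrogen proves to matter in a way the earlier swap on the benzyl ring could not show: replacing 4-methoxybenzyl with 4-sulfamoylphenyl gives an at least 3.5-fold higher number from compound 2 to compound 3 (0.54 log units; beyond the scatter), while the earlier change gave only a 1.2-fold higher number from compound 1 to compound 2 (0.07 log units; within the scatter). Measured against the chloro compound, the same replacement gives an at least 4.1-fold higher number from compound 1 to compound 3 (0.61 log units; beyond the scatter), so the weaker result does not depend on which of the two benzyl compounds serves as the reference. The reading for compound 3 is a limit of the assay and not a number, so both steps give only a minimum size: the limit of > 100000 nM in this assay, at which 1 of the 3 values shown sits.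

This replacement alters two things at once, the benzyl for a phenyl directly on the nitrogen and the methoxy or chloro for a sulfamoyl group, and the compounds shown cannot separate the two. From the compounds shown here alone, a 4-sulfamoylbenzyl group or a 4-methoxyphenyl group on the same nitrogen would tell them apart, and whether a carboxylic acid or an amine in place of the sulfamoyl group behaves the same way also remains open.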